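A few compounds are considered here, and "the series" means these few. Any claim that something is new, unique, unknown or untested is made for them only; others in the source may bear on it.

In an ADME assay on MRC5 cells (Homo sapiens) for cytotoxicity, read by fluorescence and resazurin assay, with a stated time of 3 days (on this read-out higher numbers stand for weaker inhibition and lower numbers for stronger inhibition), compound 1 `COc1ccc(Oc2cccc(CN3CCC(n4cc(C)c(=O)[nH]c4=O)CC3)c2)cc1` gives 28000 nM and compound 3 `COc1cccc(Oc2cccc(CN3CCC(n4cc(C)c(=O)[nH]c4=O)CC3)c2)c1` gives 25300 nM. These two values lie within the scatter of each other, as a 1.1-fold lower number from compound 1 to compound 3 (0.04 log units; within the scatter) shows. Compound 2 `Cc1cn(C2CCN(Cc3cccc(Oc4ccccn4)c3)CC2)c(=O)[nH]c1=O` returns only a limit, > 64000 nM. Compound 3 therefore stands level with compound 1 and clear of that limit, with an at least 2.5-fold lower number from compound 2 to compound 3 (0.40 log units; beyond the scatter), while an at least 2.2-fold higher number from compound 1 to compound 2 (0.35 log units; beyond the scatter) runs the opposite way. Compound 4 `Cc1cn(C2CCN(Cc3cccc(OC4CCCCC4)c3)CC2)c(=O)[nH]c1=O` has cyclohexyl in place of 3-methoxyphenyl on an oxygen on an aromatic ring. Among the measured compounds shown here, no measured step makes this exact change, so the closest guide is the small step to compound 3, a 1.1-fold lower number from compound 1 to compound 3 (0.04 log units; within the scatter). The expected change is none beyond the scatter, a 1.1-fold lower number from compound 3 to compound 4 (0.02 log units; within the scatter). For compound 4 the estimate is 24000 nM, with an expected range of 10000 nM to 58000 nM.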

Compound 4, half-maximal inhibitory concentration: 23600 nM
Compound 4: middle estimate off by 1.0-fold (0.01 log units), on the high side; measured number inside the range.
By their numbers in this assay, from the lowest: compounds 4, 3 and 1 (each within the scatter of the next). At a limit, above all of these: compound 2.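

The earlier compounds shown here carried only aromatic rings on this oxygen; compound 4 shows that in this assay a non-aromatic cyclohexyl ring stays within the scatter of both methoxyphenyl groups, with a 1.1-fold lower number from compound 3 to compound 4 (0.03 log units; within the scatter) and a 1.2-fold lower number from compound 1 to compound 4 (0.07 log units; within the scatter). The gap to the pyridin-2-yl group remains, with an at least 2.7-fold lower number from compound 2 to compound 4 (0.43 log units; beyond the scatter). Compound 2 gives only a limit, so that step is a bound: the limit of > 64000 nM in this assay, at which 1 of the 4 values shown sits.

From the compounds shown here alone, it remains open whether an amine or a carboxylic acid on the cyclohexyl ring, or a longer chain in its place, would move the number beyond the scatter.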